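The source may hold more compounds than are shown below. What is called first, only, known or untested is meant among the compounds shown, and "the series" means these compounds.

Of the compounds shown here, two that share one core have been tested in a functional assay on MDA-MB-231 cells (Homo sapiens) for inhibition, read by sulforhodamine B assay, tested at 10 uM; a higher number here means more inhibition at the concentration tested (going by the name of the read-out), a lower number less inhibition. In this assay compound 1 `CN(C)c1ccc(C2CC(c3ccc(-n4cncn4)cc3)=NN2S(=O)(=O)c2ccc(F)cc2)cc1` gives 12.1%. Compound 2 `CN(C)c1ccc(C2CC(c3ccc(-n4cncn4)cc3)=NN2S(=O)(=O)c2ccc(C#N)cc2)cc1` gives 32.8%, the higher of the two numbers. Going by the values given here, the only measured step, a number 20.7 percentage points higher from compound 1 to compound 2 (beyond the scatter), changes the substituent on the same aromatic carbon that changes again here. Compound 3 `CN(C)c1ccc(C2CC(c3ccc(-n4cncn4)cc3)=NN2S(=O)(=O)c2ccc(OC(F)(F)F)cc2)cc1` differs from compound 2 by trifluoromethoxy in place of cyano on an aromatic carbon. Among the compounds with values here, no measured step exchanges cyano for trifluoromethoxy, so that single step is only a loose guide to the size of change. Compound 3 is expected to give 25%, between 8% and 45%. The expected step is a number 7.8 percentage points lower from compound 2 to compound 3 (within the scatter).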

Compound 3, a percentage reported as inhibition, at one concentration (the size of the read-out at that concentration, not a potency): 18.5%
Estimate against measurement, compound 3: 6.5 percentage points above; the measured number falls inside the stated range.
By their numbers in this assay, from the lowest: compounds 1 and 3 (each within the scatter of the next); then compound 2.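

In this assay, putting trifluoromethoxy in place of cyano at this position gives a number 14.3 percentage points lower from compound 2 to compound 3 (beyond the scatter) and so shows that a second group falls clearly short of cyano. Trifluoromethoxy in place of fluoro gives a number 6.4 percentage points higher from compound 1 to compound 3 (within the scatter) and so does not separate these two groups. Nothing available explains why cyano stands apart from both.

The compounds shown leave open how an amine or a carboxylic acid at this position would compare with cyano, and whether either would stand with fluoro and trifluoromethoxy instead.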